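The source may hold more compounds than are shown below. What is called first, only, known or untested is meant among the compounds shown, and "the series" means these compounds.

Compound 1 `CC(Cl)CC(=O)NC1=C(C#N)C(c2ccc(Cl)cc2Cl)C2=C(CCCC2=O)N1c1ccc(S(N)(=O)=O)cc1` and compound 2 `NC1=C(C(=O)O)C(c2ccc(Cl)cc2Cl)C2=C(CCCC2=O)N1c1ccc(S(N)(=O)=O)cc1` share one core and were both tested in a functional assay on Ehrlich cells (Mus musculus) for cytotoxicity, read by trypan blue exclusion, with a stated time of 2 h, tested at 50 ug/mL; a higher number here means a stronger effect of the compound at the concentration tested, a lower number a weaker effect. In this assay, among the compounds with values here, compound 1 gives 55%, while compound 2 gives 10%; of these two numbers the one for compound 1 is the higher, and the gap between them lies well beyond the usual scatter of repeated measurements. Compound 3 `CN(C)c1ccc(/C=N/C2=C(C#N)C(c3ccc(Cl)cc3Cl)C3=C(CCCC3=O)N2c2ccc(S(N)(=O)=O)cc2)cc1` has not been measured yet. It differs from compound 1 in a single place: a group of 11 heavy atoms (9 carbon, 2 nitrogen; one six-membered aromatic ring of carbon only) in place of a group of 7 heavy atoms (4 carbon, 1 nitrogen, 1 oxygen, 1 chlorine; no ring), on a double-bonded ring carbon. The group that leaves carries one hydrogen-bond donor; the group that enters carries none and brings an aromatic ring with it. Within the data shown here, the two measured compounds differ from each other in another place, so they give no direct guide to this particular change, and no measured step is available to lean on. Compound 3 is expected to stay close to compound 1, with a step of a number 10 percentage points lower from compound 1 to compound 3 (within the scatter) that is expected to be small, pointing slightly downward and staying within the scatter. The value of compound 3 in this assay is estimated at 45%, with a range from 20% to 70%.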

Compound 3, a percentage reported as activity, at one concentration (the size of the read-out at that concentration, not a potency): 30%
Estimate against measurement, compound 3: 15 percentage points above; low and high end bracket the measured number.
By their numbers in this assay, from the lowest: compound 2; then compound 3; then compound 1.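

In this assay, placing the new aromatic group on the double-bonded ring carbon next to the ring nitrogen, where compound 1 carries ((2-chloropropyl)carbonyl)amino, gives a number 25 percentage points lower from compound 1 to compound 3 (beyond the scatter), so the group at this position does matter for the read-out. The effect is reduced rather than gone, since compound 3 still gives 30%, which shows that some effect at this concentration can remain without the chlorine-bearing chain and without the hydrogen-bond donor of the leaving group. No measurement shown here explains why the number falls at this position.

This single change removes the chlorine, the amide hydrogen and the carbonyl together while bringing in an aromatic ring, so the step cannot be assigned to any one of these features. A plain acetylamino group would keep the amide but lack the chlorine, and a benzylideneamino group without the dimethylamino substituent would keep the ring alone, so these two groups could begin to separate those contributions.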